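The source may hold more compounds than are shown below. What is called first, only, known or untested is meant among the compounds shown, and "the series" means these compounds.

Measured so far in a functional assay on Jurkat cells (Homo sapiens) for antiproliferative activity, read by MTT assay; a lower number here means a stronger inhibitor, a higher number a weaker inhibitor:
Compound 1, `COc1ccc(/C=C2\CCc3cc(OC)c(OC)cc3C2=O)cc1`, gives > 50000 nM, which is a limit of the assay.
Compound 2, `COc1cc2c(cc1OC)C(=O)/C(=C/c1ccc(O)cc1)CC2`, gives 19000 nM.
Compound 3, `COc1cc2c(cc1OC)C(=O)/C(=C/c1ccc(N)cc1)CC2`, gives 40000 nM.

Compound 3 stands highest of the two numbers; its nearest neighbour is compound 2, reached by a 2.1-fold higher number from compound 2 to compound 3 (0.32 log units; beyond the scatter). Against compound 1 only an at least 1.2-fold lower number from compound 1 to compound 3 (0.09 log units; that floor lies within the scatter) can be stated, since compound 1 sits at the limit of > 50000 nM in this assay, at which 1 of the 3 values shown sits. Compound 4, `COc1cc2c(cc1OC)C(=O)/C(=C/c1cc(C)cc(C)c1)CC2`, carries 3,5-dimethylphenyl in place of 4-aminophenyl on a double-bonded chain carbon bound to a double-bonded ring carbon. For the measured compounds named here, none of the measured steps exchanges the whole aryl group; the steps at hand, an at least 2.6-fold lower number from compound 1 to compound 2 (0.42 log units; beyond the scatter), an at least 1.2-fold lower number from compound 1 to compound 3 (0.09 log units; that floor lies within the scatter) and a 2.1-fold higher number from compound 2 to compound 3 (0.32 log units; beyond the scatter), each concern a single substituent on that ring and move the number only modestly. Compound 4 is therefore expected to remain in the weak range, with no change at the digits printed from compound 3 to compound 4 (within the scatter) not beyond the scatter. Compound 4 is estimated at 40000 nM, between 12000 nM and 130000 nM.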

Compound 4, half-maximal inhibitory concentration: 4000 nM
Compound 4: the middle estimate sits 10-fold (1.00 log units) above what was measured, outside the stated range (below it).
By their numbers in this assay, from the lowest: compound 4; then compound 2; then compound 3. At a limit, above all of these: compound 1.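

In this assay, replacing the whole aryl group on the double-bonded chain carbon shifts the number beyond the scatter (a 10-fold lower number from compound 3 to compound 4 (1.00 log units; beyond the scatter)) and (a 4.8-fold lower number from compound 2 to compound 4 (0.68 log units; beyond the scatter)), so this position tolerates more than single-substituent exchange on the 4-substituted rings and 3,5-dimethylphenyl gives the lowest number in the set. The third step (an at least 12-fold lower number from compound 1 to compound 4 (1.09 log units; beyond the scatter)) is only a floor, compound 1 being at a limit: the limit of > 50000 nM in this assay, at which 1 of the 4 values shown sits. Going by these compounds, it remains open whether this gain needs both methyl groups, and whether phenyl without substituents or 3,5-dichlorophenyl would keep it.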